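Swapping a ring-bearing amine for an open-chain one

This account rests on a few compounds, and the source may have more. Where it says the series, first, only, none or still open, it means among the compounds named here.

Compound 2 `O[C@H]1Cc2ccccc2C1NC1CCN(CCCc2c[nH]c3ccc(-n4cnnc4)cc23)CC1` was tested in an assay on CHO cells for displacement of a labelled ligand from 5-hydroxytryptamine receptor 1B (Homo sapiens) (a lower number here means a stronger inhibitor, a higher number a weaker inhibitor), where compound 2 gives 300 nM. Among the three compounds measured so far this is the second highest number. Compound 1 `COC[C@H](NC1CCN(CCCc2c[nH]c3ccc(Cn4cncn4)cc23)CC1)c1ccc(F)cc1` gives 1200 nM in this assay, and compound 3 `CC(=O)Nc1ccc(CNC2CCN(CCCc3c[nH]c4ccc(-n5cnnc5)cc34)CC2)cc1` gives 45 nM. The step from compound 2 to compound 3 is a direct comparison: a 6.7-fold lower number from compound 2 to compound 3 (0.82 log units; beyond the scatter), where the change was 4-acetamidobenzyl in place of 2-hydroxy-2,3-dihydro-1H-inden-1-yl on an amine nitrogen.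

Compound 4 `CC(C)=CCN(C)C1CCN(CCCc2c[nH]c3ccc(-n4cnnc4)cc23)CC1` differs from compound 2 as follows: methyl(3-methylbut-2-en-1-yl)amino in place of (2-hydroxy-2,3-dihydro-1H-inden-1-yl)amino on a saturated ring carbon. Going by the values given here, the only measured step that touches the same position is the one from compound 2 to compound 3, and it replaced the same departing group with another ring-bearing group rather than with an open chain carrying no hydrogen-bond donors. That step shows the departing group is not required for a low number, but it does not show how an open chain with a double bond behaves here, so the direction of the step to compound 4 is uncertain and a wide range is appropriate.

Compound 4 is estimated to give 250 nM in this assay, with a range from 60 nM to 1000 nM. This estimate implies an expected step of a 1.2-fold lower number from compound 2 to compound 4 (0.08 log units; within the scatter).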

Compound 4, half-maximal inhibitory concentration: 41 nM
Compound 4: middle estimate off by 6.1-fold (0.79 log units), on the high side, and the stated range ends above it.
By their numbers in this assay, from the lowest: compounds 4 and 3 (each within the scatter of the next); then compound 2; then compound 1.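

Within this assay, methyl(3-methylbut-2-en-1-yl)amino in place of (2-hydroxy-2,3-dihydro-1H-inden-1-yl)amino on this saturated ring carbon gives a 7.3-fold lower number from compound 2 to compound 4 (0.86 log units; beyond the scatter) and shows that a low number at this position does not need a ring in the group, a hydrogen-bond donor in it or a defined stereocentre. Compound 3 (45 nM) and compound 4 (41 nM) lie within the usual scatter of each other, so a group with an aromatic ring and an open chain with none can reach the same level here, which the step to compound 3 alone could not show. No measurement available here explains why the number changes with this swap.

The new group differs from the old one in several ways at once, so the compounds shown leave open whether the double bond, the methyl on the nitrogen or simply the smaller size goes with the lower number. A saturated 3-methylbutyl chain on the same nitrogen, or a plain dimethylamino group at this position, would begin to pull those features apart.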